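Compound 4: a methoxyphenyl in place of a chlorophenyl

The compounds below may be only part of what the source reports. "The series", "measured", "known", "first", "only" and "open" are said of these compounds alone.

Compound 1 `COc1cccc(OC)c1OCCNCCOc1ccccc1OCc1cccc(Cl)c1` gives 0.159 nM in an assay on CHO cells for displacement of a labelled ligand from Alpha-1B adrenergic receptor (Homo sapiens); on this read-out higher numbers stand for weaker inhibition and lower numbers for stronger inhibition.
Compound 2 `COc1cccc(OC)c1OCCNCCOc1ccccc1OCc1ccc([N+](=O)[O-])cc1` gives 0.398 nM in this assay.
Compound 3 `COc1cccc(COc2ccccc2OCCNCCOc2c(OC)cccc2OC)c1` gives 2 nM in this assay.

Compound 1 has the lowest number of the three, which here means the strongest inhibition. Its nearest neighbour is compound 2, with a 2.5-fold higher number from compound 1 to compound 2 (0.40 log units; beyond the scatter), and its furthest is compound 3, with a 13-fold higher number from compound 1 to compound 3 (1.10 log units; beyond the scatter). Compound 4 `COc1ccc(COc2ccccc2OCCNCCOc2c(OC)cccc2OC)cc1` has not yet been measured. Compared with compound 1, it shows (4-methoxyphenyl in place of 3-chlorophenyl on a saturated chain carbon bound to an oxygen on an aromatic ring).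

For the measured compounds named here, two measured steps bear on this change. The exchange of chloro for methoxy on the aromatic ring, giving the 3-methoxyphenyl group of compound 3, produced a 13-fold higher number from compound 1 to compound 3 (1.10 log units; beyond the scatter), a large loss. A different group at the same place, the 4-nitrophenyl of compound 2, produced only a 2.5-fold higher number from compound 1 to compound 2 (0.40 log units; beyond the scatter). The gap between those two groups was a 5.0-fold higher number from compound 2 to compound 3 (0.70 log units; beyond the scatter). A methoxyphenyl group therefore seems to weaken inhibition markedly, so compound 4 is expected to show a clear rise in the number from compound 1, a 9.4-fold higher number from compound 1 to compound 4 (0.97 log units; beyond the scatter). Compound 4 is estimated at 1.5 nM, within 0.4 nM to 6 nM.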

Compound 4, inhibition constant: 0.398 nM
Beside the measured number, compound 4's estimate is 3.8-fold (0.58 log units) above it, outside the stated range (below it).
By their numbers in this assay, from the lowest: compound 1; then compounds 2 and 4 (each within the scatter of the next); then compound 3.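

The place of the methoxy group on the phenyl ring matters here: changing 3-methoxyphenyl to 4-methoxyphenyl gives a 5.0-fold lower number from compound 3 to compound 4 (0.70 log units; beyond the scatter) in this assay although both groups hold the same atoms. The large loss seen with the 3-methoxyphenyl group therefore does not extend to every methoxyphenyl group, as the 4-methoxyphenyl group costs only a 2.5-fold higher number from compound 1 to compound 4 (0.40 log units; beyond the scatter) against the 3-chlorophenyl group. Methoxy in place of nitro on an aromatic carbon gives no change at the digits printed from compound 2 to compound 4 (within the scatter) so these two groups cannot be told apart here.

The compounds shown leave open how a 4-chlorophenyl or a 3-nitrophenyl group would compare, which would show whether ring place matters for other groups too. Nothing measured here says why the two methoxyphenyl groups differ.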